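The source may hold more compounds than are shown below. What is called first, only, known or untested is meant among the compounds shown, and "the series" means these compounds.

Measured compounds:
- compound 3 `COc1ccc(-c2cc(-c3ccc(C4NC(=O)c5ccccc5N4)cc3)nc(N)n2)cc1`: 124000 nM
- compound 1 `CC1(c2ccc(Nc3nc(N4CCCc5ccccc54)nc(N4CCCc5ccccc54)n3)cc2)NC(=O)c2ccccc2N1`: "not determined" (no result reported)
- compound 2 `CC1(c2ccc(NC(c3ccncc3)c3nnnn3C(C)(C)C)cc2)NC(=O)c2ccccc2N1`: "not determined" (no result reported)

Three compounds share a common amide-bearing core, and only one of them carries a number. In an ADME assay on Vero cells (Chlorocebus sabaeus) for cytotoxicity, read by MTT assay, with a stated time of 72 h (on this read-out higher numbers stand for lower toxicity in this test and lower numbers for higher toxicity in this test), compound 3 gives 124000 nM, a high concentration, which on this read-out places it at the low-toxicity end of what the assay can show. Compound 1 and compound 2 were run without a reported result, so compound 3 stands alone: it is neither more nor less toxic than anything measured beside it, and no pattern across the series can be drawn from a single number.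

Compound 4 `Nc1nc(-c2ccc(Br)cc2)cc(-c2ccc(C3NC(=O)c4ccccc4N3)cc2)n1` is the next compound to be tested. It differs from compound 3 in one place: bromo in place of methoxy on an aromatic carbon. For the measured compounds named here, nothing measured here tells how such a swap moves the result, so the expectation rests on the single value of compound 3 and on the usual scatter of the assay. The step from compound 3 to compound 4 is expected to be a 1.2-fold lower number from compound 3 to compound 4 (0.09 log units; within the scatter), that is, no change beyond the scatter in either direction. For compound 4 the expected result in this assay is therefore 100000 nM, with a range from 40000 nM to 250000 nM.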

Compound 4, half-maximal cytotoxic concentration: > 400000 nM
Compound 4: no number, only a limit (the forecaster's own chance of this, stated with the estimate: 20%); middle value at least 4.0-fold (0.60 log units) away from the limit.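

For the compounds shown here, replacing 4-methoxyphenyl with 4-bromophenyl gives an at least 3.2-fold higher number from compound 3 to compound 4 (0.50 log units; beyond the scatter), the first single change that can be read, and it shows that this position on the ring can move the result in this assay beyond the usual scatter. For compound 4, > 400000 nM is a limit of the assay and not a number. The direction of the step is therefore settled, toward lower toxicity in this test, while its full size remains unknown, and the result belongs with the one value shown at that limit: the limit of > 400000 nM in this assay, at which 1 of the 4 values shown sits.

A single swap cannot separate the effect of adding bromo from the effect of losing methoxy, and these compounds give no cause for the shift. As far as these compounds go, it remains open whether a chloro, a hydroxyl, an amine or a carboxylic acid at the same place would give a result closer to that of compound 3 or to that of compound 4, and whether the same swap would act the same way on a different core.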